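Fluoro for iodo on a weakly cytotoxic series

This account rests on a few compounds, and the source may have more. Where it says the series, first, only, none or still open, it means among the compounds named here.

Compound 1 `Cn1c([N+](=O)[O-])cnc1/C=C/c1ccccc1`: > 100000 nM (a limit of the assay)
Compound 2 `Cc1cccc(/C=C/c2ncc([N+](=O)[O-])n2C)c1`: 30900 nM
Compound 3 `Cn1c([N+](=O)[O-])cnc1/C=C/c1cccc(I)c1`: 31600 nM
Compound 4 `Cn1c([N+](=O)[O-])cnc1/C=C/c1cccc(F)c1`: not yet measured

In an ADME assay on HeLa cells (Homo sapiens) for cytotoxicity, read by resazurin assay, with a stated time of 2 days (a higher number here means a weaker inhibitor, a lower number a stronger inhibitor), compound 3 stands level with the methyl-bearing member of the set, the record showing a 1.0-fold higher number from compound 2 to compound 3 (0.01 log units; within the scatter). Only the limit reached by the hydrogen-bearing parent lies apart from this pair.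

The next structural change gives compound 4, with fluoro in place of iodo on an aromatic carbon, meta to a large group: fluoro in place of iodo on an aromatic carbon. Going by the values given here, no fluoro compound has yet been measured, so the guidance is indirect. Methyl in place of hydrogen gave an at least 3.2-fold lower number from compound 1 to compound 2 (0.51 log units; beyond the scatter), and iodo in place of hydrogen gave an at least 3.1-fold lower number from compound 1 to compound 3 (0.50 log units; beyond the scatter). Two different groups thus landed at the same level, while the parent stayed at its limit.

The new group may keep part of that gain or lose it, so a modest move toward a higher number is expected, no larger than the reverse of the hydrogen-to-iodo step. The expected step is a 1.7-fold higher number from compound 3 to compound 4 (0.24 log units; within the scatter) in this estimate. Compound 4 is estimated at 55000 nM, with an expected range from 25000 nM to 120000 nM.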

Compound 4, half-maximal inhibitory concentration: > 100000 nM
Compound 4 ended at the assay's limit (the forecaster's own chance of this, stated with the estimate: 30%); middle value at least 1.8-fold (0.25 log units) from the limit.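

In this assay, fluoro in place of iodo gives an at least 3.1-fold higher number from compound 3 to compound 4 (0.50 log units; beyond the scatter), and fluoro in place of methyl gives an at least 3.2-fold higher number from compound 2 to compound 4 (0.51 log units; beyond the scatter). The earlier compounds shown here showed only that iodo and methyl, on an aromatic carbon meta to a large group, both stood apart from the hydrogen-bearing compound 1; compound 4 shows that not every group at this place does so, and that the lower number seen with compound 2 and compound 3 does not follow from replacing hydrogen alone. The step from compound 1 to compound 4 cannot be read, so fluoro and hydrogen cannot be ordered against each other, and the two compounds share one ceiling of the assay: the limit of > 100000 nM in this assay, at which 2 of the 4 values shown sit.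

As far as these compounds go, how high the true numbers of compound 1 and compound 4 lie remains open, and so does any difference between them. From the compounds shown here alone, whether chloro or bromo at this same place would stay with iodo and methyl or fall in with fluoro also stays open, as does the outcome for a methoxy group, an amine or a carboxylic acid there.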